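Chloro to bromo exchange in the series

The compounds below may be only part of what the source reports. "The series", "measured", "known", "first", "only" and "open" are said of these compounds alone.

In a functional assay on SW-620 cells (Homo sapiens) for cytotoxicity, read by MTT assay, with a stated time of 72 h (a higher number here means a weaker inhibitor, a lower number a stronger inhibitor), compound 1 `COc1cccc(/C=C2\CCC/C(=C\c3ccc(Br)cc3)C2=O)c1OC` gives 11100 nM, compound 2 `COc1cc(/C=C2\CCC/C(=C\c3cccc(OC)c3OC)C2=O)ccc1O` gives 8600 nM and compound 3 `COc1ccc(/C=C2\CCC/C(=C\c3ccc(Cl)cc3)C2=O)cc1OC` gives 5900 nM. Compound 3 lies within the scatter of both other compounds, so these three values set no order.

Compound 4 `COc1ccc(/C=C2\CCC/C(=C\c3ccc(Br)cc3)C2=O)cc1OC` differs from compound 3 in one place: bromo in place of chloro on an aromatic carbon, para to a large group (bromo in place of chloro on an aromatic carbon). For the measured compounds named here, no chloro and bromo pair on an otherwise identical structure has been measured. The nearest evidence is a 1.3-fold lower number from compound 1 to compound 2 (0.11 log units; within the scatter), with 4-hydroxy-3-methoxyphenyl in place of 4-bromophenyl, and that step stays within the scatter. Compound 1 also carries 4-bromophenyl but differs from compound 3 in more than one place, and the two values lie within the scatter of each other.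

No step beyond the scatter is therefore expected in this assay, and the expected size is a 1.2-fold higher number from compound 3 to compound 4 (0.06 log units; within the scatter). Compound 4 is estimated at 6800 nM, with an expected range of 3500 nM to 13000 nM.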

Compound 4, half-maximal inhibitory concentration: 5200 nM
Compound 4: middle estimate off by 1.3-fold (0.12 log units), on the high side; measured number inside the range.
By their numbers in this assay, from the lowest: compounds 4, 3, 2 and 1 (each within the scatter of the next, the first and the last beyond it).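

For the compounds shown here, the first matched pair for this exchange, 4-chlorophenyl to 4-bromophenyl on the shared core, gives in this assay a 1.1-fold lower number from compound 3 to compound 4 (0.05 log units; within the scatter), so the earlier comparisons, all of which differed in more than this one place, are now joined by a direct reading of the halogen alone. At this position, on an aromatic carbon para to a large group, chloro and bromo cannot be told apart in this cytotoxicity read-out, at least with the rest of the structure held as in compound 3. No measured property is available that bears on this result.

From the compounds shown here alone, whether the same holds on the core of compound 1 remains open. Also open, going by these compounds, is whether an amine, a carboxylic acid or a longer chain in place of the halogen would produce a step beyond the scatter.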